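Acylguanidine series: hydroxy on the piperidine ring of compound 3

The source may hold more compounds than are shown below. What is called first, only, known or untested is meant among the compounds shown, and "the series" means these compounds.

Measured in a functional assay for inhibition of sodium/hydrogen exchanger (Oryctolagus cuniculus); a lower number here means a stronger inhibitor, a higher number a weaker inhibitor:
compound 1 `CCc1cc(Cl)c(S(C)(=O)=O)cc1C(=O)N=C(N)N` gives 63 nM
compound 2 `CCc1cc(OC)c(S(C)(=O)=O)cc1C(=O)N=C(N)N` gives 30 nM
compound 3 `CCc1cc(N2CCCCC2)c(S(C)(=O)=O)cc1C(=O)N=C(N)N` gives 25 nM

Compound 3 has the lowest number of the three. Its separation from compound 1 is clear, a 2.5-fold lower number from compound 1 to compound 3 (0.40 log units; beyond the scatter), but its separation from compound 2 is not, a 1.2-fold lower number from compound 2 to compound 3 (0.08 log units; within the scatter), so compound 2 and compound 3 cannot be told apart on these numbers.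

Compound 4 `CCc1cc(N2CCC(O)CC2)c(S(C)(=O)=O)cc1C(=O)N=C(N)N` carries one change relative to compound 3: hydroxy in place of hydrogen on a saturated ring carbon. For the measured compounds named here, no measured step touches the saturated ring; all three known steps vary the group on the aromatic carbon, a 2.1-fold lower number from compound 1 to compound 2 (0.32 log units; beyond the scatter), a 2.5-fold lower number from compound 1 to compound 3 (0.40 log units; beyond the scatter) and a 1.2-fold lower number from compound 2 to compound 3 (0.08 log units; within the scatter), and the last of these shows that methoxy and piperidin-1-yl there give much the same number. Going by the values given here, the step to compound 4 therefore rests on no direct precedent, and in this assay no step beyond the scatter is expected, no change at the digits printed from compound 3 to compound 4 (within the scatter). Compound 4 is estimated at 25 nM, with a range from 10 nM to 65 nM.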

Compound 4, half-maximal inhibitory concentration: 41 nM
Estimate against measurement, compound 4: 1.6-fold (0.21 log units) below, within the range that was stated.
By their numbers in this assay, from the lowest: compounds 3, 2, 4 and 1 (each within the scatter of the next, the first and the last beyond it).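

In this assay, for the compounds shown here, this is the first reading on the saturated ring, and hydroxy on a ring carbon three ring bonds from the ring nitrogen gives no step beyond the scatter (a 1.6-fold higher number from compound 3 to compound 4 (0.21 log units; within the scatter)). With 4-hydroxypiperidin-1-yl on the aromatic carbon, compound 4 cannot be told apart from the methoxy compound (a 1.4-fold higher number from compound 2 to compound 4 (0.14 log units; within the scatter)) or from the chloro compound (a 1.5-fold lower number from compound 1 to compound 4 (0.19 log units; within the scatter)), although compound 3 is separated from compound 1 beyond the scatter. No measurement bears on the reason for any of these steps.

From the compounds shown here alone, it remains open whether an amine, a carboxylic acid or a longer chain on the same ring carbon would give a step beyond the scatter. Also open, going by these compounds, is whether hydroxy on another carbon of the piperidine ring would read the same.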